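From Aminophenyl to Difluorophenyl: An Expected Step

The compounds below may be only part of what the source reports. "The series", "measured", "known", "first", "only" and "open" are said of these compounds alone.

Compound 1 `COc1ccc(-c2cc(/C=C/C(=O)c3ccc(N)cc3)[nH]n2)cc1` and compound 2 `COc1cc(-c2cc(/C=C/C(=O)c3ccc(N)cc3)[nH]n2)cc(OC)c1OC` were both tested in a functional assay on NCI-H522 cells (Homo sapiens) for cytotoxicity, read by sulforhodamine B assay, with a stated time of 48 h, tested at 100 uM; a lower number here means a stronger effect, a higher number a weaker effect of the compound at the concentration tested. In this assay compound 1 gives -75%, and compound 2 gives -83%. Compound 2 holds the lower of the two numbers, but compound 1 sits within the scatter of it, so the two cannot be ordered. Compound 3 `COc1cc(-c2cc(/C=C/C(=O)c3ccc(F)c(F)c3)[nH]n2)cc(OC)c1OC` differs from compound 2 by 3,4-difluorophenyl in place of 4-aminophenyl on a carbonyl carbon. Going by the values given here, no measured pair shows a step of this kind. In this assay a modest shift toward a weaker effect is expected, the estimated step being a number 18 percentage points higher from compound 2 to compound 3 (beyond the scatter). Compound 3 is therefore expected to give -65%, estimated between -95% and -15%.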

Compound 3, a percentage reported as activity, at one concentration (the size of the read-out at that concentration, not a potency): -53%
Estimate against measurement, compound 3: 12 percentage points below, and the stated range covers the measured number.
By their numbers in this assay, from the lowest: compounds 2 and 1 (each within the scatter of the next); then compound 3.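

Compound 1 and compound 2 both carry 4-aminophenyl on the carbonyl carbon, so they showed nothing about this position. In this assay, 3,4-difluorophenyl in place of 4-aminophenyl gives a number 30 percentage points higher from compound 2 to compound 3 (beyond the scatter), showing that the read-out responds to the group held here, although compound 3 still gives -53%. Nothing shown explains this shift.

A single pair cannot separate the loss of the amino group from the arrival of the two fluorines. From the compounds shown here alone, how an unsubstituted phenyl or a 4-hydroxyphenyl on the same carbonyl carbon would read remains open.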